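The source may report more compounds than this note shows. Statements on the series, on what has been measured and on what is new or still open speak of the compounds shown alone.

Measured so far in a functional assay on UACC-62 cells (Homo sapiens) for cytotoxicity, read by sulforhodamine B assay, with a stated time of 48 h; a higher number here means a weaker inhibitor of growth, a lower number a stronger inhibitor of growth:

Compound 1 `Nc1nc(Cl)c2ncn(Cc3ccc(CCl)cc3)c2n1` gives 8130 nM.
Compound 2 `ClCc1cccc(Cn2cnc3c(Cl)nc(Cl)nc32)c1` gives 3460 nM.
Compound 3 `ClCc1ccc(Cn2cnc3c(Cl)nc(Cl)nc32)cc1` gives 4370 nM.

All three compounds share a core of two fused rings carrying a benzyl group with a chloromethyl substituent. Compound 2 and compound 3 are built from the same atoms joined differently; the difference between the two cores is not broken down here, and their values lie within the scatter of each other. Compound 1 is made from compound 3 by one change, (amino in place of chloro on an aromatic carbon). That change produced a 1.9-fold higher number from compound 3 to compound 1 (0.27 log units; within the scatter), a step that stays within the usual scatter.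

Compound 4 `Nc1nc(Cl)c2ncn(Cc3cccc(CCl)c3)c2n1` has not yet been measured. It is made from compound 2 by amino in place of chloro on an aromatic carbon, the same change at the same place as before. Within the data shown here, only one earlier example of this change is available, so the expectation rests on a single pair. The step from compound 2 to compound 4 is expected to be a 1.9-fold higher number from compound 2 to compound 4 (0.28 log units; within the scatter), because the earlier step of a 1.9-fold higher number from compound 3 to compound 1 (0.27 log units; within the scatter) was small. Compound 4 is therefore estimated to give 6600 nM in this assay, most likely between 3000 nM and 14000 nM.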

Compound 4, concentration for total growth inhibition: 4780 nM
Estimate against measurement, compound 4: 1.4-fold (0.14 log units) above; the measured number falls inside the stated range.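

In this assay putting amino in place of chloro on an aromatic carbon, between two ring nitrogen atoms, gives a 1.4-fold higher number from compound 2 to compound 4 (0.14 log units; within the scatter) and so leaves the number within the usual scatter. The same change on the two cores gives steps that do not differ from each other: the same change on two cores in this assay, a 1.9-fold higher number (0.27 log units; within the scatter) from compound 3 to compound 1 and a 1.4-fold higher number (0.14 log units; within the scatter) from compound 2 to compound 4, 1.3-fold (0.13 log units) apart, within the scatter of two such steps. Among these compounds, this shows that, on these two closely related cores, the change carried over from one to the other with no sign of a different outcome, but it rests on only two pairs, does not show that the change has any real effect on growth inhibition in either core, and says nothing about a third core.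

From the compounds shown here alone, only chloro and amino appear at this place, so a methoxy group or a methylamino group there remains open. Every compound also carries the chloromethyl group, which leaves open what a plain methyl or a hydroxymethyl group would give in its stead.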